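From methoxy to amino on a shared core

A few compounds are considered here, and "the series" means these few. Any claim that something is new, unique, unknown or untested is made for them only; others in the source may bear on it.

In an ADME assay on Vero cells (Chlorocebus sabaeus) for cytotoxicity, with a stated time of 5 days (a higher number here means a weaker inhibitor, a lower number a stronger inhibitor), compound 1 (`COc1nc(NC2CC2)c2ncn([C@H]3C[C@H](N=[N+]=[N-])[C@@H](CO)O3)c2n1`) gives > 100000 nM as a limit of the assay. Compound 2 (`COc1nc(OC)c2ncn([C@H]3C[C@H](N=[N+]=[N-])[C@@H](CO)O3)c2n1`) gives > 100000 nM which is likewise a limit. For the measured compounds named here, the only measured step is a step that the two limits leave unreadable from compound 1 to compound 2 and so it offers no size to carry over. Compound 3 (`COc1nc(N)c2ncn([C@H]3C[C@H](N=[N+]=[N-])[C@@H](CO)O3)c2n1`) has amino in place of methoxy on an aromatic carbon of compound 2 (amino in place of methoxy on an aromatic carbon) and keeps the rest. With compound 1 and compound 2 both at the limit of > 100000 nM in this assay, at which 2 of the 2 values shown sit, no step beyond the scatter is expected in this assay here. The estimate is a number no higher from compound 2 to compound 3 (the limit leaves the size open) for this swap. Compound 3 is expected at 100000 nM with an estimated range of 40000 nM to 150000 nM in this assay.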

Compound 3, half-maximal inhibitory concentration: > 100000 nM
Compound 3: only a limit was reported (the forecaster's own chance of this, stated with the estimate: 80%); the middle value lies on the limit itself.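

Compound 1, compound 2 and compound 3 all stop at the same assay limit, so no step between them can be read: the limit of > 100000 nM in this assay, at which 3 of the 3 values shown sit.

What the compounds shown leave open is how far apart they truly lie in this assay.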